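Swapping the Amide Substituent of an Inactive Oxime Amidine

A few compounds are considered here, and "the series" means these few. Any claim that something is new, unique, unknown or untested is made for them only; others in the source may bear on it.

Compound 1, `O/N=C(/Nc1cccc(Br)c1)c1ccc2occc2c1`, gives 1100 nM in an assay on tissue (HeLa cells) for inhibition of Indoleamine 2,3-dioxygenase 1 (Homo sapiens), read by spectrophotometry; a higher number here means a weaker inhibitor, a lower number a stronger inhibitor. Compound 2, `O/N=C(/Nc1cccc(C(F)(F)F)c1)c1ccc2occc2c1`, gives 1900 nM. Compound 3, `O=C(NCC1CCCCC1)c1cccc(N/C(=N/O)c2ccc3occc3c2)c1`, gives > 30000 nM, which is a limit of the assay rather than a measured number.

Compounds 1 and 2 differ in a single group, trifluoromethyl in place of bromo on an aromatic carbon, and the step of a 1.7-fold higher number from compound 1 to compound 2 (0.24 log units; within the scatter) lies within the scatter. Compound 3 carries an amide group instead and sits at the limit: the limit of > 30000 nM in this assay, at which 1 of the 3 values shown sits.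

Compound 4, `CC1CCN(C(=O)c2cccc(N/C(=N/O)c3ccc4occc4c3)c2)CC1`, differs from compound 3 by 4-methylpiperidin-1-yl in place of (cyclohexylmethyl)amino on a carbonyl carbon. For the measured compounds named here, the only measured step, from compound 1 to compound 2, changes a different part of the shared core, so no measured step bears directly on this amide change; the one measured amide-bearing compound, compound 3, gives only a limit.

With compound 3 at > 30000 nM and the change confined to the amide substituent, compound 4 is expected to remain at or near the limit. The estimate for compound 4 is 30000 nM, with a range from 8000 nM to 100000 nM. This estimate means a step of a number no higher from compound 3 to compound 4 (the limit leaves the size open), that is, no change expected beyond the scatter.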

Compound 4, half-maximal inhibitory concentration: > 30000 nM
Compound 4: no number, only a limit (the forecaster's own chance of this, stated with the estimate: 70%); the middle value sits exactly at the limit.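

In this assay compound 4 gives > 30000 nM, which is a limit of the assay and not a number. Placing (4-methylpiperidin-1-yl)carbonyl on the aromatic carbon in place of bromo gives an at least 27-fold higher number from compound 1 to compound 4 (1.43 log units; beyond the scatter), and placing it there in place of trifluoromethyl gives an at least 15-fold higher number from compound 2 to compound 4 (1.19 log units; beyond the scatter), so this amide costs far more than the exchange of the two smaller groups, which gave a 1.7-fold higher number from compound 1 to compound 2 (0.24 log units; within the scatter). The step between the two amides cannot be read, since both compounds give only limits, but the result does add one thing: the (cyclohexylmethyl)amino group of compound 3 has the amide hydrogen and 4-methylpiperidin-1-yl has none, and the two compounds still end in the same place, so the presence of that hydrogen does not rescue or separate them in this assay: the limit of > 30000 nM in this assay, at which 2 of the 4 values shown sit.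

The compounds shown leave open whether the loss comes with any amide at this aromatic carbon or only with large substituents on it, which a plain primary amide or an N-methyl amide could help to settle. They also leave open how a carboxylic acid or a nitrile would behave at the same carbon.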